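Chloro for fluoro across two benzothiazole amide cores

The source may report more compounds than this note shows. Statements on the series, on what has been measured and on what is new or still open speak of the compounds shown alone.

Measured so far:
- compound 1 `O=C(Nc1nc2ccc(Cl)cc2s1)c1cn(-c2ccccc2)nc1-c1ccc(F)cc1`: 45700 nM
- compound 2 `O=C(Nc1nc2ccc(Cl)cc2s1)c1cn(-c2ccccc2)nc1-c1ccc(Cl)cc1`: 15700 nM
- compound 3 `COc1ccc(-c2nn(-c3ccccc3)cc2C(=O)Nc2nc3ccc(F)cc3s2)cc1`: 15400 nM

In an ADME assay on HEK-293T cells (Homo sapiens) for cytotoxicity, read by MTT assay, with a stated time of 72 h (a lower number here means a stronger inhibitor, a higher number a weaker inhibitor), compound 1 gives 45700 nM and compound 2 gives 15700 nM. The difference between them is chloro in place of fluoro on an aromatic carbon, and the step is a 2.9-fold lower number from compound 1 to compound 2 (0.46 log units; beyond the scatter). Compound 3 gives 15400 nM in this assay; its core and the core of compound 1 differ in more than one place, and that difference is not broken down here. Compound 3 and compound 2 lie within the scatter of each other.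

Compound 4 `COc1ccc(-c2nn(-c3ccccc3)cc2C(=O)Nc2nc3ccc(Cl)cc3s2)cc1` is not yet measured. It differs from compound 3 by chloro in place of fluoro on an aromatic carbon. This is the same kind of change as from compound 1 to compound 2, but not the same: there the carbon sits para to a large group on a ring of carbon only, here it sits on a ring that is part of a fused or bridged system of two rings, meta to a fused ring and para to a fused ring. Among the measured compounds shown here, only the one step of a 2.9-fold lower number from compound 1 to compound 2 (0.46 log units; beyond the scatter) is available to rest on, and it was made at a different place. The expectation for compound 4 is therefore a modest lowering of a 1.7-fold lower number from compound 3 to compound 4 (0.23 log units; within the scatter), smaller than the earlier step and hedged widely. The estimate for compound 4 in this assay is 9000 nM, expected to fall between 4000 nM and 25000 nM.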

Compound 4, half-maximal inhibitory concentration: 12600 nM
Beside the measured number, compound 4's estimate is 1.4-fold (0.15 log units) below it; low and high end bracket the measured number.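

Set side by side in this assay, the two steps of chloro in place of fluoro do not differ by more than two such steps scatter: the same change on two cores in this assay, a 2.9-fold lower number (0.46 log units; beyond the scatter) from compound 1 to compound 2 and a 1.2-fold lower number (0.09 log units; within the scatter) from compound 3 to compound 4, 2.4-fold (0.38 log units) apart, within the scatter of two such steps. The earlier step therefore carries to the second core without a demonstrable difference, although a 1.2-fold lower number from compound 3 to compound 4 (0.09 log units; within the scatter) is within the scatter on its own, whereas the earlier step is beyond it. One pair of steps, made at two different places, does not show that the change has the same size on both cores, nor that it would hold on any other core in the series.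

With the chloro on the benzothiazole held fixed, the group on the other ring gives a 1.2-fold lower number from compound 2 to compound 4 (0.10 log units; within the scatter) and a 3.6-fold lower number from compound 1 to compound 4 (0.56 log units; beyond the scatter), so only the second of these lies beyond the scatter. Going by these compounds, how an amine, a carboxylic acid or an alkoxy group with a longer chain than methoxy would read at that place remains open.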